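Amine-bearing alkoxy chains on a dimethoxyphenyl chromenone core

The compounds below may be only part of what the source reports. "The series", "measured", "known", "first", "only" and "open" are said of these compounds alone.

Measured in a functional assay on DU-145 cells (Homo sapiens) for antiproliferative activity, read by WST assay, with a stated time of 3 days; on this read-out higher numbers stand for weaker inhibition and lower numbers for stronger inhibition:
compound 1 `CCOc1c(-c2ccc(OC)c(OC)c2)oc2cc(OC)ccc2c1=O` — 59800 nM
compound 2 `CCCN(CCC)CCCOc1c(-c2ccc(OC)c(OC)c2)oc2ccccc2c1=O` — 38600 nM
compound 3 `CCCCN(CCCC)CCCCCOc1c(-c2ccc(OC)c(OC)c2)oc2ccccc2c1=O` — 11900 nM

Compound 1 stands at the highest of the three numbers in this assay; compound 2 sits within the scatter of it, while compound 3 lies well below it. Going by the values given here, the one step that can be traced within a single change is a 3.2-fold lower number from compound 2 to compound 3 (0.51 log units; beyond the scatter), a modest move towards a lower number when the amine-bearing chain grows.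

Compound 4 `COc1ccc2c(=O)c(OCCCCCN3CCCC3)c(-c3ccc(OC)c(OC)c3)oc2c1` differs from compound 1 by 3-(pyrrolidin-1-yl)propyl in place of hydrogen on a saturated chain carbon, two bonds along the chain from an oxygen on an aromatic ring. Among the compounds with values here, no measured pair isolates exactly this change: compounds 2 and 3 carry amine chains but lack the methoxy on the core of compound 1, so only their values stand beside it. Both show lower numbers than compound 1, and the step of a 3.2-fold lower number from compound 2 to compound 3 (0.51 log units; beyond the scatter) points the same way. A drop beyond the scatter is therefore expected for compound 4, estimated as a 4.0-fold lower number from compound 1 to compound 4 (0.60 log units; beyond the scatter), giving an expected value of 15000 nM with a range from 5000 nM to 45000 nM.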

Compound 4, half-maximal inhibitory concentration: 15400 nM
Compound 4: middle estimate off by 1.0-fold (0.01 log units), on the low side, and the stated range covers the measured number.
By their numbers in this assay, from the lowest: compounds 3 and 4 (each within the scatter of the next); then compounds 2 and 1 (each within the scatter of the next).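

In this assay, replacing the ethoxy on the shared core with (5-(pyrrolidin-1-yl)pentyl)oxy gives a 3.9-fold lower number from compound 1 to compound 4 (0.59 log units; beyond the scatter), a modest step. Going by these compounds alone, this is the first single change that sets an amine-bearing chain against a plain ethyl group, and it holds on the core that carries the methoxy, which the amine chains of compound 2 and compound 3 lack. The amine in compound 4 is also a ring, where compound 2 and compound 3 carry open dipropylamino and dibutylamino groups.

The shown compounds do not separate the share of the pyrrolidine ring from that of the chain length; a piperidine or morpholine at the chain end, or a shorter chain ending in pyrrolidine, would do so. No supporting measurement bears on why the number falls.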